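Ester Variation on a Shared Core in Rabbit Kidney Cells

A few compounds are considered here, and "the series" means these few. Any claim that something is new, unique, unknown or untested is made for them only; others in the source may bear on it.

Measured compounds:
compound 1 `Nc1ncnc2c1ncn2CC(O)C(=O)OCCO` — > 400 ug/mL
compound 2 `COC(=O)C(O)Cn1cnc2c(N)ncnc21` — > 400 ug/mL

Compound 1 was tested in a functional assay on PRK cells (Oryctolagus cuniculus) for cytotoxicity (a lower number here means that less compound is tolerated, a higher number that more compound is tolerated), and gave > 400 ug/mL, which is a limit of the assay rather than a number. Compound 2, which carries hydrogen in place of hydroxymethyl on a saturated chain carbon bound to an oxygen next to a carbonyl group, gave > 400 ug/mL in this assay, again a limit. The step that the two limits leave unreadable from compound 1 to compound 2 therefore cannot be read, since the limit of > 400 ug/mL in this assay, at which 2 of the 2 values shown sit, is all that either value shows.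

Compound 3 `CC(C)COC(=O)C(O)Cn1cnc2c(N)ncnc21` has not been measured. Against compound 1 it shows (isopropyl in place of hydroxymethyl on a saturated chain carbon bound to an oxygen next to a carbonyl group). Going by the values given here, the only measured step at this position, from compound 1 to compound 2, is unreadable, so there is no evidence of any size of change in this assay tied to changes at this place. On the two limits shown, compound 3 is expected to sit at or near the same limit, with a step of a number no higher from compound 1 to compound 3 (the limit leaves the size open) that is expected to stay within the scatter. For compound 3 the estimate in this assay is therefore 400 ug/mL, with a range from 150 ug/mL to 800 ug/mL.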

Compound 3, minimum cytotoxic concentration: > 400 ug/mL
Compound 3 ended at the assay's limit; the forecaster's own chance of this, stated with the estimate: 75%; the middle value sits exactly at the limit.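

Going by these compounds alone, no step among compound 1, compound 2 and compound 3 can be read in this assay, since all three values are limits and not numbers: the limit of > 400 ug/mL in this assay, at which 3 of the 3 values shown sit.

The compounds shown leave open the concentration at which any of them would become cytotoxic, and whether changing the ester on the shared core makes any difference in this assay.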